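A few compounds are considered here, and "the series" means these few. Any claim that something is new, unique, unknown or untested is made for them only; others in the source may bear on it.

Compound 2 `N#CC1=C(N)N(c2ccc(S(N)(=O)=O)cc2)C2=C(CCCC2)C1c1ccc([N+](=O)[O-])cc1` has been measured in a functional assay on Ehrlich cells (Mus musculus) for cytotoxicity, read by trypan blue exclusion, with a stated time of 2 h, tested at 100 ug/mL (on this read-out higher numbers stand for a stronger effect at the one concentration tested and lower numbers for a weaker effect), where compound 2 gives 20%. Within the data shown here, its only neighbour is compound 1 `N#CC1=C(N)N(c2ccc(S(N)(=O)=O)cc2)C2=C(CCCC2)C1c1ccccc1`, which in this assay gives 30%; the step of a number 10 percentage points lower from compound 1 to compound 2 (within the scatter) is within the scatter, so the two are not separated. Compound 3 `N#CC1=C(N)N(c2ccc(S(N)(=O)=O)cc2)C2=C(CCCC2)C1c1ccc(Cl)cc1Cl` differs from compound 2 by 2,4-dichlorophenyl in place of 4-nitrophenyl on a saturated ring carbon. Among the measured compounds shown here, no measured step exchanges one aryl group on that saturated ring carbon for another, and the one step known did not move the read-out beyond the scatter, so compound 3 is expected to stay close, with a number 5 percentage points higher from compound 2 to compound 3 (within the scatter). Compound 3 is estimated at 25%, between 5% and 50%.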

Compound 3, a percentage reported as activity, at one concentration (the size of the read-out at that concentration, not a potency): 70%
The estimate for compound 3 lay 45 percentage points below the measured number, outside the stated range (above it).
By their numbers in this assay, from the lowest: compounds 2 and 1 (each within the scatter of the next); then compound 3.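

On the saturated ring carbon, the aryl group can move the read-out in this assay far more than the earlier nitro-for-hydrogen change did. Exchanging 4-nitrophenyl for 2,4-dichlorophenyl gives a number 50 percentage points higher from compound 2 to compound 3 (beyond the scatter) and exchanging phenyl for 2,4-dichlorophenyl gives a number 40 percentage points higher from compound 1 to compound 3 (beyond the scatter) so the same change stands out against both earlier aryl groups. Nothing available accounts for this rise.

As far as these compounds go, it remains open whether 4-chlorophenyl or 2-chlorophenyl alone would match 2,4-dichlorophenyl. Also open, from the compounds shown here alone, is what 4-methoxyphenyl or a propyl chain would give on that carbon.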